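This account rests on a few compounds, and the source may have more. Where it says the series, first, only, none or still open, it means among the compounds named here.

Series notes. Compound 1 `COc1ccc2nc(NC(=O)CCCCCCC(=O)NO)sc2c1` gives 1.25 ug/mL in a functional assay on NCI-H460 cells (Homo sapiens) for cytotoxicity; on this read-out higher numbers stand for weaker inhibition and lower numbers for stronger inhibition. Compound 2 `O=C(CCCCCCC(=O)Nc1nc2ccccc2s1)NO` gives 5.71 ug/mL in this assay, and compound 3 `Cc1ccc2nc(NC(=O)CCCCC(=O)NO)sc2c1` gives 11 ug/mL in this assay. Compound 3 thus has the highest of the three numbers: its gap to compound 2 is within the scatter, its gap to compound 1 beyond it. Among the compounds with values here, the single one-point step measured so far, a 4.6-fold higher number from compound 1 to compound 2 (0.66 log units; beyond the scatter), concerns the group sitting on the same aromatic carbon and was modest.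

Compound 4 `O=C(CCCCC(=O)Nc1nc2ccc([N+](=O)[O-])cc2s1)NO` differs from compound 3 by nitro in place of methyl on an aromatic carbon. Within the data shown here, the only step that bears on this, a 4.6-fold higher number from compound 1 to compound 2 (0.66 log units; beyond the scatter), shows that exchanging the group on this aromatic carbon moves the number modestly, but a nitro group has no precedent and the direction of this exchange cannot be read off the measured pairs. A modest step in this assay, in either direction and possibly within the scatter, is expected, a 1.1-fold higher number from compound 3 to compound 4 (0.04 log units; within the scatter). Compound 4 is therefore estimated at 12 ug/mL, with a range from 4 ug/mL to 36 ug/mL.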

Compound 4, half-maximal inhibitory concentration: > 30 ug/mL
Compound 4: no number, only a limit (the forecaster's own chance of this, stated with the estimate: 5%); at least 2.5-fold (0.39 log units) between middle value and limit.
By their numbers in this assay, from the lowest: compound 1; then compounds 2 and 3 (each within the scatter of the next). At a limit, above all of these: compound 4.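

Nitro in place of methyl on this aromatic carbon gives an at least 2.7-fold higher number from compound 3 to compound 4 (0.43 log units; beyond the scatter), so the direction that could not be read beforehand is now known for this exchange, and a second pair of compounds shows that the group at this position can move the number beyond the scatter. Compound 4 has no number in this assay, only a limit: the limit of > 30 ug/mL in this assay, at which 1 of the 4 values shown sits. Nitro brings three heavy atoms and two hydrogen-bond acceptors where methyl brings one heavy atom and none, but nothing here ties the step to either count.

From the compounds shown here alone, how far the step extends remains open, since only its lower bound can be read. An amine on this aromatic carbon, or nitro paired with a longer chain, would show whether the step holds beyond this single pair.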